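The source may report more compounds than this note shows. Statements on the series, on what has been measured and on what is new or still open speak of the compounds shown alone.

Measured in a functional assay on MCF7 cells (Homo sapiens) for inhibition; a higher number here means a weaker inhibitor, a lower number a stronger inhibitor:
- Compound 1 `Oc1cccc(-c2nc3cc(F)ccc3s2)c1`: 570 nM
- Compound 2 `COc1ccc(-c2cc(=O)c3cc(F)ccc3o2)cc1OC`: 83400 nM

Of the two, compound 1 has the lower number in this assay and is the stronger inhibitor. Compound 2, at 83400 nM, is the weaker inhibitor, and the gap between the two lies well beyond the scatter.

Compound 3 `Oc1ccc(-c2nc3cc(F)ccc3s2)cc1O` has not yet been measured. It departs from compound 1 by a single change, hydroxy in place of hydrogen on an aromatic carbon, ortho to a hydroxy group and para to a large group.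

Within the data shown here, no measured pair shows what this change does, so the expectation rests on compound 1 alone, at 570 nM. The likeliest outcome is no step beyond the scatter, although a moderate step in either direction remains possible, with a slight lean towards weaker inhibition. The expected step is a 1.2-fold higher number from compound 1 to compound 3 (0.09 log units; within the scatter). For compound 3 the estimated value is 700 nM, with an expected range from 90 nM to 5000 nM.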

Compound 3, half-maximal inhibitory concentration: 720 nM
Compound 3: middle estimate off by 1.0-fold (0.01 log units), on the low side; measured number inside the range.
By their numbers in this assay, from the lowest: compounds 1 and 3 (each within the scatter of the next); then compound 2.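

In this assay, hydroxy in place of hydrogen on an aromatic carbon, ortho to a hydroxy group and para to a large group, gives a 1.3-fold higher number from compound 1 to compound 3 (0.10 log units; within the scatter). Among these compounds, this aromatic carbon therefore takes a second hydroxy group without a change that can be told from the scatter, a reading about a single position that the earlier compounds could not give. Compound 2 differs from compound 1 in more than one place, so only compound 1 and compound 3 form a pair that isolates one change, and nothing measured here speaks to the reason for this result.

The compounds shown leave open whether this tolerance extends beyond hydroxy, for instance to a methoxy group, a fluorine atom, an amine or a carboxylic acid on the same aromatic carbon. They also leave open how much the hydroxy group already present in compound 1 contributes, a question that a matched compound carrying methoxy or plain hydrogen in its place could address.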